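The source may hold more compounds than are shown below. What is called first, only, known or untested is meant among the compounds shown, and "the series" means these compounds.

Compound 1 `CC[C@H](C)[C@@H](NCC(=O)NNC(=O)COc1ccc(-c2nc3ccccc3s2)cc1OC)C(=O)O` carries a shared core ending in a carboxylic acid bearing an amino group. In a functional assay on HepG2 cells (Homo sapiens) for inhibition, read by MTT assay, with a stated time of 3 days (a lower number here means a stronger inhibitor, a higher number a weaker inhibitor), compound 1 gives 3990 nM, the highest of the two numbers measured. Its nearest neighbour is compound 2 `COc1cc(-c2nc3ccccc3s2)ccc1OCC(=O)NNC(=O)CN1CCC[C@H]1C(=O)O`, which in this assay gives 2650 nM; the step of a 1.5-fold lower number from compound 1 to compound 2 (0.18 log units; within the scatter) stays within the scatter, so the two cannot be ranked.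

Compound 3 `CCOC(=O)[C@@H]1CCCN1CC(=O)NNC(=O)COc1ccc(-c2nc3ccccc3s2)cc1OC` has not been measured. It differs from compound 1 by 2-(ethoxycarbonyl)pyrrolidin-1-yl in place of (1-carboxy-2-methylbutyl)amino on a saturated chain carbon bound to a carbonyl carbon. Among the measured compounds shown here, the only measured step that bears on this is the one from compound 1 to compound 2, which exchanged the same group at the same place for 2-carboxypyrrolidin-1-yl and moved the number by a 1.5-fold lower number from compound 1 to compound 2 (0.18 log units; within the scatter), within the scatter. For the measured compounds named here, compound 3 carries the ethyl ester of that acid instead, and no measured pair shows what such an ester does here, so the expectation rests on the one small step alone. Compound 3 is therefore expected to give about 2800 nM, within a range from 1000 nM to 8000 nM. The step this estimate means, a 1.4-fold lower number from compound 1 to compound 3 (0.15 log units; within the scatter), is expected to stay within the scatter.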

Compound 3, half-maximal inhibitory concentration: 2800 nM
The estimate for compound 3 equals the measured number at the digits printed; measured number inside the range.
By their numbers in this assay, from the lowest: compounds 2, 3 and 1 (each within the scatter of the next).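

Putting ethyl in place of hydrogen on an oxygen next to a carbonyl group gives a 1.1-fold higher number from compound 2 to compound 3 (0.02 log units; within the scatter) in this assay, so at this place the carboxylic acid and its ethyl ester cannot be told apart. The full exchange of (1-carboxy-2-methylbutyl)amino for 2-(ethoxycarbonyl)pyrrolidin-1-yl gives a 1.4-fold lower number from compound 1 to compound 3 (0.15 log units; within the scatter), which also cannot be ranked. This exchange removes the free acid, adds a five-membered non-aromatic ring and takes the hydrogen-bond donors of the group from 2 to 0, yet none of these differences separates the compounds in this assay.

The compounds shown leave open whether any group on this saturated chain carbon can move the number beyond the scatter, for example a simple dimethylamino group or a longer chain carrying the carboxylic acid. They also leave open how the ethyl ester of the open-chain group of compound 1 would compare with compound 1 itself, since the only ester shown carries the ring.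

No evidence is available on why these three compounds give such similar numbers.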